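The compounds below may be only part of what the source reports. "The series", "measured", "known", "first", "only" and "open" are said of these compounds alone.

Of the compounds shown here, three sharing a pair of 4-bromophenyl-bearing sulfonamide groups have been measured in a functional assay on BXPC-3 cells (Homo sapiens) for antiproliferative activity, read by MTT assay, with a stated time of 48 h; on this read-out higher numbers stand for weaker inhibition and lower numbers for stronger inhibition. Compound 1 `Cc1c(C(=O)OCCCN(C)C)oc2ccc(N(Cc3ccc(Br)cc3)S(=O)(=O)c3ccc(Br)cc3)cc12` gives 24200 nM, compound 2 `Cc1c(C(=O)N2CCCC(C)C2)oc2ccc(N(Cc3ccc(Br)cc3)S(=O)(=O)c3ccc(Br)cc3)cc12` gives 16700 nM and compound 3 `CN(C)CCNC(=O)c1nc2cc(N(Cc3ccc(Br)cc3)S(=O)(=O)c3ccc(Br)cc3)ccc2o1` gives 13700 nM. Compound 3 lies within the scatter of both others, so these numbers set no ranking among the three.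

Compound 4 `CN1CCC(NC(=O)c2nc3cc(N(Cc4ccc(Br)cc4)S(=O)(=O)c4ccc(Br)cc4)ccc3o2)CC1` keeps the core of compound 3 and carries 1-methylpiperidin-4-yl in place of 2-(dimethylamino)ethyl on an amide-type nitrogen.

Within the data shown here, only one measured step bears on this change, and it does so indirectly. In a 1.4-fold lower number from compound 1 to compound 2 (0.16 log units; within the scatter), 3-methylpiperidin-1-yl replaces 3-(dimethylamino)propoxy on a carbonyl carbon, which also exchanges an open dimethylamino chain for a six-membered ring, and the step stays within the scatter. Among the measured compounds shown here, no measured pair shows this exact change on the amide-type nitrogen, so the evidence is thin.

On the strength of that small step, and starting from compound 3 at 13700 nM, no shift beyond the scatter is expected in this assay. The expected step is a 1.1-fold lower number from compound 3 to compound 4 (0.02 log units; within the scatter), an estimate that stays within the scatter. For compound 4 the estimated value is 13000 nM, with an expected range from 6000 nM to 28000 nM.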

Compound 4, half-maximal inhibitory concentration: 10200 nM
Compound 4: middle estimate off by 1.3-fold (0.11 log units), on the high side; measured number inside the range.
By their numbers in this assay, from the lowest: compounds 4, 3, 2 and 1 (each within the scatter of the next, the first and the last beyond it).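

Among these compounds, this is the first step read directly on the amide-type nitrogen, and in this assay the exchange of the open 2-(dimethylamino)ethyl chain for the 1-methylpiperidin-4-yl ring gives a 1.3-fold lower number from compound 3 to compound 4 (0.13 log units; within the scatter). Closing the chain into a six-membered non-aromatic ring, with its one ring nitrogen carrying a methyl group, therefore leaves the read-out within the scatter at this position, so the two groups cannot be told apart here on the core of compound 3. The earlier ring-for-chain step sat on a carbonyl carbon and joined a different core to a different linkage, whereas this one keeps the amide and changes only the group on its nitrogen, although no measurement at hand offers any explanation for this outcome.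

From the compounds shown here alone, what remains open is whether a morpholine ring, a carboxylic acid or a longer chain on the same amide-type nitrogen would carry the number beyond the scatter. Going by these compounds, it is equally open whether 1-methylpiperidin-4-yl would behave the same way on an amide built from the core of compound 2.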